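This account rests on a few compounds, and the source may have more. Where it says the series, first, only, none or still open, it means among the compounds named here.

Measured compounds:
- compound 1, `Cc1ccc(CNC(=O)[C@H](CCc2ccccc2)NC(=O)[C@H](CNC(=O)CC(C)(C)C)NC(=O)C(=O)c2c[nH]c3ccccc23)cc1`: "not determined" (no result reported)
- compound 2, `CC(C)(C)CNC(=O)C[C@H](NC(=O)CN1CCCCC1)C(=O)N[C@@H](CCc1ccccc1)C(=O)NCc1ccccc1`: 62 nM
- compound 3, `CC(C)(C)CNC(=O)C[C@H](NC(=O)c1ccc(OCc2ccccc2)cc1)C(=O)N[C@@H](CCc1ccccc1)C(=O)NCc1ccccc1`: 22 nM

Three compounds share a common peptide-like core and were tested in an assay on HEK293 cells for inhibition of nuclear factor NF-kappa-B complex (Homo sapiens), read by a luciferase reporter, with stated times of 1 h and 3 h; on this read-out higher numbers stand for weaker inhibition and lower numbers for stronger inhibition. Compound 1 carries an indole glyoxyl amide at one end, but no result was reported for it. Of the two compounds with numbers, compound 2 has the higher one, so it is the weaker inhibitor of the pair, and compound 3 has the lower one, beyond the usual scatter.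

Compound 4, `CC(C)(C)CNC(=O)C[C@H](NC(=O)C(=O)c1c[nH]c2ccccc12)C(=O)N[C@@H](CCc1ccccc1)C(=O)NCc1ccccc1`, is the next compound to be tested. It differs from compound 2 in one place: (1H-indol-3-yl)carbonyl in place of (piperidin-1-yl)methyl on a carbonyl carbon. Among the measured compounds shown here, no measured pair illustrates exactly this exchange. For the measured compounds named here, still, the only other compound with a number, compound 3, gives 22 nM, which suggests that changes at this end of the core can move the number downward beyond the scatter. On that basis a moderate step toward stronger inhibition, a 2.5-fold lower number from compound 2 to compound 4 (0.39 log units; beyond the scatter), is expected for compound 4. The estimate for compound 4 in this assay is 25 nM, with a plausible range from 8 nM to 80 nM.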

Compound 4, half-maximal inhibitory concentration: 25 nM
Beside the measured number, compound 4's estimate shows no gap at the digits printed, within the range that was stated.
By their numbers in this assay, from the lowest: compounds 3 and 4 (each within the scatter of the next); then compound 2.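

In this assay, among the compounds shown here, compound 4 gives the first direct reading of a single exchange on this carbonyl carbon: (1H-indol-3-yl)carbonyl in place of (piperidin-1-yl)methyl produces a 2.5-fold lower number from compound 2 to compound 4 (0.39 log units; beyond the scatter), a modest move toward stronger inhibition. The position therefore accepts the loss of the non-aromatic ring and the arrival of a larger group with two aromatic rings, a double bond outside those rings and a hydrogen-bond donor. All of these features change in one step, and no measurement shown explains the shift in potency.

The compounds shown do not separate the contribution of the indole rings from that of the added carbonyl. They also leave open how this position would respond to a carboxylic acid or a simple primary amine.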